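The compounds below may be only part of what the source reports. "The series", "measured", "known", "first", "only" and "open" are said of these compounds alone.

In a functional assay on A549 cells (Homo sapiens) for antiproliferative activity, read by MTT assay, with a stated time of 72 h (on this read-out higher numbers stand for weaker inhibition and lower numbers for stronger inhibition), compound 1 `COc1cc(-c2ncnn2-c2cccc(F)c2)cc(OC)c1OC` gives > 10000 nM, which is a limit of the assay and not a number. Compound 2 `COc1cc(-c2ncnn2-c2ccc(Cl)cc2Cl)cc(OC)c1OC` gives > 10000 nM, which is likewise a limit. Among the compounds with values here, compound 3 `COc1ccc(-c2ncnn2-c2cc(OC)c(OC)c(OC)c2)cc1` gives 520 nM, the only actual number in this small set, so it can be ranked against the other two only through (the limit of > 10000 nM in this assay, at which 2 of the 3 values shown sit).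

Compound 4 `COc1cccc(-c2ncnn2-c2cc(OC)c(OC)c(OC)c2)c1` keeps the atoms of compound 3 but joins them differently: 3-methoxyphenyl in place of 4-methoxyphenyl on an aromatic carbon. It has 3-methoxyphenyl in place of 4-methoxyphenyl on an aromatic carbon of a five-membered aromatic ring with 3 nitrogen.

Within the data shown here, the one measured step, a step that the two limits leave unreadable from compound 1 to compound 2, offers little guidance. Its size cannot be read, and it concerns a group on an aromatic nitrogen rather than the aromatic carbon that changes here. The data therefore give no measured size for this kind of change, and any forecast is loose. The step of a 5.8-fold higher number from compound 3 to compound 4 (0.76 log units; beyond the scatter) is expected to lead towards weaker inhibition in this assay, beyond the usual scatter, and it may reach the limit of the assay. For compound 4 the estimated value is 3000 nM, with an expected range from 450 nM to 12000 nM.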

Compound 4, half-maximal inhibitory concentration: > 10000 nM
Compound 4 was reported as a limit (the forecaster's own chance of this, stated with the estimate: 35%); middle value at least 3.3-fold (0.52 log units) away from the limit.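

In this assay, within the data shown here, 3-methoxyphenyl in place of 4-methoxyphenyl on an aromatic carbon of the five-membered ring gives an at least 19-fold higher number from compound 3 to compound 4 (1.28 log units; beyond the scatter), the first step in this set whose size can be read at all, and it is large although the two compounds hold the same atoms. Among these compounds, the placing of the single methoxy group on this phenyl ring therefore matters a great deal in this pair, and of the two arrangements only the 4-methoxyphenyl one gives an actual number. Compound 4 gives a limit and not a number, so the step is only a lower bound, and compound 4 joins the compounds that sit at that limit: the limit of > 10000 nM in this assay, at which 3 of the 4 values shown sit.

Going by these compounds, how much weaker compound 4 really is stays open, and one pair cannot say whether the same preference would hold with other groups on the shared core. Also open, on these data alone, is how a 4-ethoxyphenyl, a 4-hydroxyphenyl or a 4-aminophenyl group would stand on this aromatic carbon, since the 4-methoxyphenyl group is the only one here that gives a number.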